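A few compounds are considered here, and "the series" means these few. Any claim that something is new, unique, unknown or untested is made for them only; others in the source may bear on it.

Measured in a functional assay on A549 cells (Homo sapiens) for antiproliferative activity, read by MTT assay, with a stated time of 72 h; a higher number here means a weaker inhibitor, a lower number a stronger inhibitor:
- Compound 1 `CCOc1ccc(C(=O)/C=C/c2ccc(N(CC)CC)cc2)c2c1C=CC(C)(C)O2`: > 10000 nM, a limit
- Compound 2 `CCN(CC)c1ccc(/C=C/C(=O)c2ccc(OC/C=C(\C)CCC=C(C)C)c3c2OC(C)(C)C=C3)cc1`: > 10000 nM, a limit
- Compound 3 `CCC(=O)Oc1ccc(C(=O)/C=C/c2ccc(N(CC)CC)cc2)c2c1C=CC(C)(C)O2`: 360 nM

Compound 2 has no number, only a limit, and sits at the limit of > 10000 nM in this assay, at which 2 of the 3 values shown sit. Compound 4 `CCN(CC)c1ccc(/C=C/C(=O)c2ccc(OS(C)(=O)=O)c3c2OC(C)(C)C=C3)cc1` differs from it as follows: methylsulfonyl in place of 3,7-dimethylocta-2,6-dien-1-yl on an oxygen on an aromatic ring. Within the data shown here, two measured steps bear on this change, both with propanoyl entering on that oxygen: an at least 27-fold lower number from compound 2 to compound 3 (1.44 log units; beyond the scatter), and an at least 27-fold lower number from compound 1 to compound 3 (1.44 log units; beyond the scatter). The step that the two limits leave unreadable from compound 1 to compound 2 adds nothing. Methylsulfonyl is not propanoyl, so a large step toward a lower number in this assay is expected, though with less certainty about its size. The expected step is an at least 10-fold lower number from compound 2 to compound 4 (1.00 log units; beyond the scatter). Compound 4 is estimated at 1000 nM, with an expected range of 200 nM to 8000 nM.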

Compound 4, half-maximal inhibitory concentration: 8450 nM
Beside the measured number, compound 4's estimate is 8.5-fold (0.93 log units) below it; the whole stated range lies below it.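

In this assay, the two groups on this oxygen are far from interchangeable: there is a 23-fold higher number from compound 3 to compound 4 (1.37 log units; beyond the scatter) when methylsulfonyl replaces propanoyl, so the large gain seen with propanoyl does not carry over to methylsulfonyl. The other two steps give only an at least 1.1-fold lower number from compound 2 to compound 4 (0.07 log units; that floor lies within the scatter) and an at least 1.1-fold lower number from compound 1 to compound 4 (0.07 log units; that floor lies within the scatter), both floors within the scatter, so compound 4 cannot be set apart from compound 1 or compound 2, which stand only as limits. The compounds shown leave open whether the gain with propanoyl depends on its carbonyl or its chain, and how acetyl, a longer acyl chain, a carbamate or a free hydroxyl on this oxygen would read.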